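Compound 3 to compound 4: a change of side group

The source may report more compounds than this note shows. Statements on the series, on what has been measured and on what is new or still open speak of the compounds shown alone.

Measured in an ADME assay on MT4 cells (Homo sapiens) for cytotoxicity, read by MTT assay, with a stated time of 3 days; on this read-out higher numbers stand for lower toxicity in this test and lower numbers for higher toxicity in this test:
- compound 1 `CC(C)(C)NC(=O)COC(=O)c1ccc([N+](=O)[O-])o1`: > 100000 nM, a limit
- compound 2 `CCC(C)(C)NC(=O)COC(=O)c1ccc([N+](=O)[O-])o1`: > 100000 nM, a limit
- compound 3 `CC(C)(C)N(CCCc1ccccc1)C(=O)COC(=O)c1ccc([N+](=O)[O-])o1`: "not active" (no number reported), no number

Compound 3 has no single number to stand on, and the other two results are not numbers either: the limit of > 100000 nM in this assay, at which 2 of the 3 values shown sit. Compound 4 `CC(=O)Oc1ccc(CN(C(=O)COC(=O)c2ccc([N+](=O)[O-])o2)C(C)(C)C)cc1` differs from compound 3 by one change, with 4-acetoxyphenyl in place of phenethyl on a saturated chain carbon bound to an amide-type nitrogen. Going by the values given here, the only measured step is a step that the two limits leave unreadable from compound 1 to compound 2. It is a different change and gives no size to carry over. No step beyond the scatter is therefore expected in this assay, in either direction. Compound 4 is expected near 100000 nM, with an estimated range from 30000 nM to 200000 nM.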

Compound 4, half-maximal cytotoxic concentration: > 100000 nM
Compound 4: a limit, no number; the forecaster's own chance of this, stated with the estimate: 70%; the middle value lies on the limit itself.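

Compound 3 has no number and compound 4 gives only a limit, so no step can be read between them. The compounds shown leave open whether any change to the shared core would give a readable cytotoxic concentration.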